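Swapping acetyl for 1-hydroxyethyl in compound 2

The source may hold more compounds than are shown below. What is called first, only, known or untested is meant among the compounds shown, and "the series" means these compounds.

Values in a functional assay on HMEC-1 cells (Homo sapiens) for antiproliferative activity, read by cell counting, with a stated time of 4 days (a lower number here means a stronger inhibitor, a higher number a weaker inhibitor), are these:
compound 1 `CC(Nc1ccccc1Oc1ccc(Cl)cc1)=C1C(=O)CC(c2ccccc2)CC1=O` gives 260 nM
compound 2 `CC(=O)c1ccc(Oc2ccccc2NC(C)=C2C(=O)CC(c3ccccc3)CC2=O)cc1` gives 180 nM
compound 3 `CC(Nc1ccccc1Oc1ccccc1)=C1C(=O)CC(c2ccccc2)CC1=O` gives 160 nM

Compound 2 at 180 nM lies within the scatter of both other measured compounds, so no order can be read among the three. Compound 4 `CC(Nc1ccccc1Oc1ccc(C(C)O)cc1)=C1C(=O)CC(c2ccccc2)CC1=O` is the unmeasured partner of compound 2. The change between them is 1-hydroxyethyl in place of acetyl on an aromatic carbon and in words it puts 1-hydroxyethyl in place of acetyl on an aromatic carbon. Three measured steps swap groups at that same place, and a 1.4-fold lower number from compound 1 to compound 2 (0.16 log units; within the scatter) and a 1.6-fold lower number from compound 1 to compound 3 (0.21 log units; within the scatter) stay within the scatter. Given also a 1.1-fold lower number from compound 2 to compound 3 (0.05 log units; within the scatter) no step beyond the scatter is expected in this assay and no direction is favoured, though no measured compound carries 1-hydroxyethyl. The estimated step is a 1.1-fold higher number from compound 2 to compound 4 (0.05 log units; within the scatter) and it is expected to stay within the scatter. For compound 4 the estimated value is 200 nM with an expected range of 100 nM to 400 nM in this measurement.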

Compound 4, half-maximal inhibitory concentration: 140 nM
The estimate for compound 4 lay 1.4-fold (0.15 log units) above the measured number; the range from low to high includes it.
By their numbers in this assay, from the lowest: compounds 4, 3, 2 and 1 (each within the scatter of the next).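

In this assay, replacing acetyl, with no hydrogen-bond donor, by 1-hydroxyethyl, with one, gives no step beyond the scatter (a 1.3-fold lower number from compound 2 to compound 4 (0.11 log units; within the scatter)). The same holds when 1-hydroxyethyl is compared with the other two groups at this place, para to a large group (a 1.1-fold lower number from compound 3 to compound 4 (0.06 log units; within the scatter); a 1.9-fold lower number from compound 1 to compound 4 (0.27 log units; within the scatter)). The position therefore now holds hydrogen, chloro, acetyl and 1-hydroxyethyl without any order among the four compounds, and nothing available offers an explanation for this result.

The compounds shown leave open whether an amine, a carboxylic acid or a longer chain at this place would produce a step beyond the scatter. They also leave open whether 1-hydroxyethyl would behave the same way on another part of the shared core.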